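The compounds below may be only part of what the source reports. "The series", "measured", "known", "first", "only" and "open" are said of these compounds alone.

Compound 1 `O=C(O)CC(c1ccc(OCC2COc3ccc(Cl)cc3O2)cc1)c1cnco1` carries an aryl on the saturated chain carbon of the shared core; in a functional assay on HEK293 cells for agonist activity at Free fatty acid receptor 1 (Homo sapiens), read by fluorescence and calcium flux, with a stated time of 10 min (on this read-out lower numbers stand for smaller maximal responses and higher numbers for larger maximal responses), compound 1 reaches 63%. Compound 2 `Cn1cncc1C(CC(=O)O)c1ccc(OCC2COc3ccc(Cl)cc3O2)cc1` differs only at that position, and in this assay compound 2 reaches 62%. The step of a number 1 percentage points lower from compound 1 to compound 2 (within the scatter) is within the scatter. For the measured compounds named here, on the two numbers so far, compound 2 thus holds the smaller value, but only by a margin that the scatter covers, with compound 1 as its nearest neighbour.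

Compound 3 `O=C(O)CC(c1ccc(F)cc1)c1ccc(OCC2COc3ccc(Cl)cc3O2)cc1` is the next member. The change from compound 2 is 4-fluorophenyl in place of 1-methyl-1H-imidazol-5-yl on a saturated chain carbon bound to an aromatic carbon and a saturated chain carbon. Going by the values given here, only one measured step touches this position, the swap of one five-membered heteroaryl for another, and it left the maximal response unchanged beyond the scatter. Among the compounds with values here, no measured step shows what a carbon-only six-membered ring does at this place, so the expectation rests on the single flat step from compound 1 to compound 2.

For compound 3 in this assay the expected step is no change at the digits printed from compound 2 to compound 3 (within the scatter), that is no step beyond the scatter in either direction. Compound 3 is therefore estimated at 62%, with a range from 45% to 80%.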

Compound 3, largest response reached (Emax), in percent of the reference or control that the assay uses: 83%
The estimate for compound 3 lay 21 percentage points below the measured number, outside the stated range (above it).
By their numbers in this assay, from the lowest: compounds 2 and 1 (each within the scatter of the next); then compound 3.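

In this assay, the position on the saturated chain carbon bound to an aromatic carbon and a saturated chain carbon proves sensitive to the group it carries: 4-fluorophenyl in place of 1-methyl-1H-imidazol-5-yl gives a number 21 percentage points higher from compound 2 to compound 3 (beyond the scatter), and 4-fluorophenyl in place of 1,3-oxazol-5-yl gives a number 20 percentage points higher from compound 1 to compound 3 (beyond the scatter). The flat step between the two five-membered aromatic rings therefore described only part of this position, since compound 3, with its six-membered aromatic ring of carbon only, stands apart from both compound 1 and compound 2 and holds the largest maximal response of the three. No measurement at hand explains this difference, and these compounds do not separate the contributions of ring size, the absence of ring nitrogen and the fluorine.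

Still open, going by these compounds, is whether the fluorine matters, which unsubstituted phenyl at this place would help to show. Pyridyl would test a six-membered aromatic ring with a ring nitrogen, and so indicate whether the higher response follows the ring size or the carbon-only ring.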